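A few compounds are considered here, and "the series" means these few. Any claim that something is new, unique, unknown or untested is made for them only; others in the source may bear on it.

Measured so far in a functional assay on MCF7 cells (Homo sapiens), tested at 7.5 uM; on this read-out higher numbers stand for a weaker effect at the one concentration tested and lower numbers for a stronger effect:

Compound 1, `CC(C)=CCOc1c(C)c(C)c2c(c1C)CCC(C)(COc1ccc(/C=C3\SC(=O)NC3=O)cc1C)O2`: 27%
Compound 2, `C=CCOc1c(C)c(C)c2c(c1C)CCC(C)(COc1ccc(/C=C3\SC(=O)NC3=O)cc1C)O2`: 8%
Compound 3, `Cc1c(C)c2c(c(C)c1OC(=O)CCC(=O)O)CCC(C)(COc1ccc(/C=C3\SC(=O)NC3=O)cc1)O2`: 76%

Compound 1 stands second highest of the three numbers in this assay. Its nearest neighbour is compound 2, reached by a number 19 percentage points lower from compound 1 to compound 2 (beyond the scatter), a modest step beyond the scatter. Compound 3 lies furthest away, with a number well above compound 1, but the two structures differ in more than one place and no single step is shown between them.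

Compound 4, `CCOc1cc(/C=C2\SC(=O)NC2=O)ccc1OCC1(C)CCc2c(C)c(OCC=C(C)C)c(C)c(C)c2O1`, has not yet been measured. It differs from compound 1 only in this: ethoxy in place of methyl on an aromatic carbon. None of the measured steps touches this aromatic carbon; the one shown step, from compound 1 to compound 2, changes the chain on the oxygen of the shared core and says nothing about the ring that carries the ethoxy in compound 4. Going by the values given here, with no comparable step available, no shift beyond the scatter is expected in this assay, in either direction, and the range must stay wide.

Compound 4 is therefore estimated at 30% in this assay, between 10% and 55%, which means an expected step of a number 3 percentage points higher from compound 1 to compound 4 (within the scatter).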

Compound 4, a percentage reported as activity, at one concentration (the size of the read-out at that concentration, not a potency): 54%
For compound 4 the middle estimate is 24 percentage points below the measured one; measured number inside the range.
By their numbers in this assay, from the lowest: compound 2; then compound 1; then compound 4; then compound 3.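

In this assay the aromatic carbon ortho to a large group proves responsive: ethoxy in place of methyl gives a number 27 percentage points higher from compound 1 to compound 4 (beyond the scatter) and so a weaker effect at the one concentration tested. Going by these compounds alone, this is the first reading at this carbon, and it shows that the ring carrying this position can move the read-out as well as the chain on the oxygen of the shared core; it rests on a single pair, with methyl (1 heavy atom) leaving and ethoxy (3 heavy atoms, 1 hydrogen-bond acceptor) entering. No measurement is available that bears on why the number rises.

The compounds shown do not separate the added oxygen from the added carbons, which an ethyl or a methoxy group on this aromatic carbon would begin to do, and a hydrogen there would show what the methyl of compound 1 itself contributes. Also open, from the compounds shown here alone, is whether ethoxy in place of methyl gives a step of similar size when the allyl chain of compound 2 sits on the core instead of the chain of compound 1.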